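The source may hold more compounds than are shown below. What is called first, only, known or untested is meant among the compounds shown, and "the series" means these compounds.

Of the compounds shown here, three have been measured in an assay for positive allosteric modulation of metabotropic glutamate receptor 2 (Rattus norvegicus); a higher number here means that more compound is needed for the effect, a lower number that less compound is needed. Compound 1, `Cc1ncc(OCCCCOc2ccc(C(=O)CC(C)(C)C)c(O)c2C)cc1C(=O)O`, gives 28 nM. Compound 2, `Cc1c(OC[C@H](C)COc2ccc(F)c(C(=O)O)c2)ccc(C(=O)CC(C)(C)C)c1O`, gives 294 nM, and compound 3, `Cc1c(OC[C@@H](C)COc2ccc(F)c(C(=O)O)c2)ccc(C(=O)CC(C)(C)C)c1O`, gives 112 nM. Compound 3 therefore stands second highest of the three numbers: the step of a 2.6-fold lower number from compound 2 to compound 3 (0.42 log units; beyond the scatter) is a modest one, and the nearest reason that can be pointed to is the fact that compounds 2 and 3 differ only in the configuration as drawn, since nothing else separates them. Compound 1 lies further away, with a lower number than compound 3.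

The next compound, compound 4, `Cc1c(OC[C@@H](C)COc2ccc3c(c2)C(=O)NC3)ccc(C(=O)CC(C)(C)C)c1O`, differs from compound 3 in one place: a group of 10 heavy atoms (8 carbon, 1 nitrogen, 1 oxygen; one five-membered non-aromatic ring with 1 hetero atom, one six-membered aromatic ring of carbon only) in place of a group of 10 heavy atoms (7 carbon, 2 oxygen, 1 fluorine; one six-membered aromatic ring of carbon only), on an oxygen on a saturated carbon. The carboxylic acid that compounds 1, 2 and 3 all carry is thus gone, and a ring-fused amide-bearing group takes the place of the fluorinated aryl acid. Within the data shown here, none of the measured steps changes this part of the molecule; the only measured step, from compound 2 to compound 3, concerns configuration alone and says nothing about swapping one aromatic group for another. There is therefore no measured basis for the direction of the change, and the estimate for compound 4 can only be anchored loosely on compound 3 with a wide range: compound 4 is expected to give about 200 nM, between 40 nM and 1000 nM, which means an expected step of a 1.8-fold higher number from compound 3 to compound 4 (0.25 log units; within the scatter) in this assay.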

Compound 4, half-maximal effective concentration: > 10000 nM
Compound 4: a limit, no number (the forecaster's own chance of this, stated with the estimate: 10%); middle value at least 50-fold (1.69 log units) from the limit.
By their numbers in this assay, from the lowest: compound 1; then compound 3; then compound 2. At a limit, above all of these: compound 4.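

In this assay compound 4 gives > 10000 nM, which is a limit of the assay and not a number. Among these compounds, putting the ring-fused amide-bearing group, which has no carboxylic acid, in place of the 3-carboxy-4-fluorophenyl group on the oxygen on a saturated carbon gives an at least 89-fold higher number from compound 3 to compound 4 (1.95 log units; beyond the scatter), a far larger change than the only earlier step, a 2.6-fold lower number from compound 2 to compound 3 (0.42 log units; beyond the scatter), which touched configuration alone and left this part of the molecule as it was. This shows that the group at this place can decide whether the compound gives a measurable number in this assay at all, and the step is only a minimum, with the true size unknown: the limit of > 10000 nM in this assay, at which 1 of the 4 values shown sits.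

Several things change together in this one step, since the carboxylic acid and the fluorine both leave while a second ring and an amide enter, so the compounds shown cannot say which of these changes counts. Going by these compounds, it also stays open whether a tetrazole or a methyl ester in place of the carboxylic acid, on the same fluorinated ring, would stay close to compound 3 or fall to the same limit as compound 4.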